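Chloro for Fluoro: An Estimate for Compound 4

This account rests on a few compounds, and the source may have more. Where it says the series, first, only, none or still open, it means among the compounds named here.

Values measured in an assay on U2OS cells for activation of nuclear factor erythroid 2-related factor 2 (Homo sapiens), read by beta-arrestin recruitment, with a stated time of 6 h; on this read-out higher numbers stand for an effect only at larger amounts of compound and lower numbers for an effect already at smaller amounts:
compound 1 `O=S(=O)(/C=C/c1ncccc1F)c1ccccc1F`: 176 nM
compound 2 `O=S(=O)(/C=C/c1ccccn1)c1ccc(F)cc1`: 3100 nM
compound 3 `O=S(=O)(/C=C/c1ncccc1F)c1ccccc1Cl`: 122 nM

Compound 3 arises from compound 1 by chloro in place of fluoro on an aromatic carbon. This gave a 1.4-fold lower number from compound 1 to compound 3 (0.16 log units; within the scatter). Compound 2 differs from compound 1 in its core; the difference between the two cores is not broken down here. Among the three, compound 2 gives the highest number, beyond the scatter from both compound 1 and compound 3.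

Compound 4 `O=S(=O)(/C=C/c1ccccn1)c1ccc(Cl)cc1` is not yet measured. It arises from compound 2 by chloro in place of fluoro on an aromatic carbon. This is the same kind of change as from compound 1 to compound 3, though the place differs: ortho to a large group there, para to a large group here. The earlier step of a 1.4-fold lower number from compound 1 to compound 3 (0.16 log units; within the scatter) lay within the scatter. On that basis the expected step is a 1.4-fold lower number from compound 2 to compound 4 (0.15 log units; within the scatter), about equal to it. Compound 4 is therefore estimated at 2200 nM in this assay, with a likely range from 1000 nM to 5000 nM.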

Compound 4, half-maximal effective concentration: 1730 nM
Compound 4: the middle estimate sits 1.3-fold (0.10 log units) above what was measured, within the range that was stated.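

In this assay, chloro in place of fluoro gives a 1.8-fold lower number from compound 2 to compound 4 (0.25 log units; within the scatter). Set beside the earlier case, the change looks the same on both cores: the same change on two cores in this assay, a 1.4-fold lower number (0.16 log units; within the scatter) from compound 1 to compound 3 and a 1.8-fold lower number (0.25 log units; within the scatter) from compound 2 to compound 4, 1.2-fold (0.09 log units) apart, within the scatter of two such steps. So on these two cores the swap leaves the number within the usual scatter, which means the data show no real difference between chloro and fluoro, and two cores cannot establish that this would hold on a third.

The compounds shown leave open what other groups at this place on the ring would do, such as a methyl, a methoxy or an amine. They also leave open whether chloro for fluoro would give the same result at a different place on the same core.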